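Swapping Cyclohexyl for 2-Methylphenyl on a Long-Lived Core

The source may report more compounds than this note shows. Statements on the series, on what has been measured and on what is new or still open speak of the compounds shown alone.

Compound 1, `O=C(NCC1CCCCC1)N1C(=O)c2ccccc2S1(=O)=O`, carries a cyclohexyl group on a saturated chain carbon bound to an amide-type nitrogen. In a physicochemical assay for pharmacokinetics (on this read-out lower numbers stand for a shorter-lived compound and higher numbers for a longer-lived compound), compound 1 gives > 166 h, which is a limit of the measurement rather than a number. Compound 2, `O=C(NCc1cccs1)N1C(=O)c2ccccc2S1(=O)=O`, gives > 166 h in this assay, again a limit. Compound 3, `O=C(NCc1cccc(Br)c1)N1C(=O)c2ccccc2S1(=O)=O`, gives > 166 h in this assay, also a limit. Because (the limit of > 166 h in this assay, at which 3 of the 3 values shown sit), the steps a step that the two limits leave unreadable from compound 1 to compound 2, a step that the two limits leave unreadable from compound 1 to compound 3 and a step that the two limits leave unreadable from compound 2 to compound 3 cannot be sized, and nothing shows whether any of them is larger than the scatter.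

Compound 4, `Cc1ccccc1CNC(=O)N1C(=O)c2ccccc2S1(=O)=O`, is the next compound to be measured: 2-methylphenyl in place of cyclohexyl on a saturated chain carbon bound to an amide-type nitrogen. The three measured steps are the only ones that bear on this change; each of them exchanges one group on the same chain carbon, and none moves a compound off the limit. No readable step is therefore expected here. Compound 4 is expected to reach the same limit, with an estimated 200 h and a range from 166 h to 400 h. The estimated step is a step that the limit leaves unreadable from compound 1 to compound 4.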

Compound 4, half-life: > 166 h
Compound 4: no number, only a limit (the forecaster's own chance of this, stated with the estimate: 90%); the middle value does not contradict the limit.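

In this assay compound 4 gives > 166 h, again a limit. The steps joining compound 1, compound 2 and compound 3 to compound 4 therefore cannot be read: the limit of > 166 h in this assay, at which 4 of the 4 values shown sit. The compounds shown leave open how long each one actually lasts, and whether exchanging the group on the chain carbon changes the half-life at all.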